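A few compounds are considered here, and "the series" means these few. Any claim that something is new, unique, unknown or untested is made for them only; others in the source may bear on it.

Measured so far in an assay on liver for binding affinity to Alpha-1B adrenergic receptor (Homo sapiens), using microsomes; a higher number here means a weaker inhibitor, a lower number a stronger inhibitor: compound 1 `COC(=O)C1=C(C)NC(=O)N(C(=O)NCCCN2CCN(c3ccccc3O)CC2)C1c1ccc(F)c(F)c1` gives 16 nM; compound 2 `COC(=O)C1=C(C)NC(=O)N(C(=O)NCCCN2CCN(c3ccc(Cl)cc3)CC2)C1c1ccc(F)c(F)c1` gives 17 nM; compound 3 `COC(=O)C1=C(C)NC(=O)N(C(=O)NCCCN2CCN(c3cccc(Cl)c3)CC2)C1c1ccc(F)c(F)c1` gives 8.4 nM.

Compound 3 holds the lowest of the three numbers. The step of a 1.9-fold lower number from compound 1 to compound 3 (0.28 log units; within the scatter) stays within the scatter, whereas the step of a 2.0-fold lower number from compound 2 to compound 3 (0.31 log units; beyond the scatter) lies just beyond it, a modest gap. Compound 4 `COC(=O)C1=C(C)NC(=O)N(C(=O)NCCCN2CCN(c3ccc(OC)cc3C)CC2)C1c1ccc(F)c(F)c1` differs from compound 3 by 4-methoxy-2-methylphenyl in place of 3-chlorophenyl on an amine nitrogen in a ring. All three measured steps concern the aryl group on that same ring nitrogen, and all are small: a 1.1-fold higher number from compound 1 to compound 2 (0.03 log units; within the scatter), a 1.9-fold lower number from compound 1 to compound 3 (0.28 log units; within the scatter) and a 2.0-fold lower number from compound 2 to compound 3 (0.31 log units; beyond the scatter). Another aryl exchange at this position is therefore expected to move this assay only modestly, and the estimated step is a 1.8-fold higher number from compound 3 to compound 4 (0.25 log units; within the scatter), most likely toward a somewhat higher number. Compound 4 is estimated at 15 nM, expected between 6 nM and 40 nM.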

Compound 4, inhibition constant: 510 nM
Estimate against measurement, compound 4: 34-fold (1.53 log units) below; the measured number lies above the stated range.
By their numbers in this assay, from the lowest: compounds 3, 1 and 2 (each within the scatter of the next, the first and the last beyond it); then compound 4.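

Within the data shown here, this position proved far less tolerant than the earlier compounds suggested: in this assay the chloro and hydroxy aryl groups stayed close together, while 4-methoxy-2-methylphenyl gives a 61-fold higher number from compound 3 to compound 4 (1.78 log units; beyond the scatter) and a 30-fold higher number from compound 2 to compound 4 (1.48 log units; beyond the scatter) and a 32-fold higher number from compound 1 to compound 4 (1.50 log units; beyond the scatter) in weakening. The loss is thus about as large from each of the three earlier aryl groups, and compound 4 stands alone as the weakest of the set. The compounds shown leave open whether the methoxy or the methyl carries this loss, as the two enter together, and how 4-methoxyphenyl or 2-methylphenyl alone would read. No measurement at hand accounts for the drop.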